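Five-Membered Ring in Place of Six: Compound 4 Assessed

The source may hold more compounds than are shown below. What is called first, only, known or untested is meant among the compounds shown, and "the series" means these compounds.

Compound 1 `c1cc(N2CCCC2)nc(Nc2ccc(Oc3ncnc4ccsc34)cc2)n1` gives 22.2% in a functional assay on HCT-116 cells (Homo sapiens) for inhibition, read by MTT assay, with a stated time of 72 h, tested at 20 uM; on this read-out lower numbers stand for less inhibition and higher numbers for more inhibition at the one concentration tested (going by the name of the read-out).
Compound 2 `c1cc(N2CCCCC2)nc(Nc2ccc(Oc3ncnc4sccc34)cc2)n1` gives 66.3% in this assay.
Compound 3 `c1cc(N2CCCCC2)nc(Nc2ccc(Oc3ncnc4ccsc34)cc2)n1` gives 61.5% in this assay.

Compound 2 stands highest of the three numbers. Its nearest neighbour is compound 3, which sits within the scatter of it, while compound 1 lies well below it, beyond the scatter.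

Compound 4 `c1cc(N2CCCC2)nc(Nc2ccc(Oc3ncnc4sccc34)cc2)n1` has not yet been measured. It differs from compound 2 by pyrrolidin-1-yl in place of piperidin-1-yl on an aromatic carbon.

Going by the values given here, two measured steps bear on this. The step of a number 4.8 percentage points lower from compound 2 to compound 3 (within the scatter) shows that the exchange on the oxygen makes no difference beyond the scatter. The step of a number 39.3 percentage points higher from compound 1 to compound 3 (beyond the scatter) is the same exchange of ring size run the other way, and it was large. Compound 4 is therefore expected to fall by a step of about that size, estimated as a number 39.3 percentage points lower from compound 2 to compound 4 (beyond the scatter) in this assay. Compound 4 is expected to give about 27%, within a range from 12% to 45%.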

Compound 4, a percentage reported as inhibition, at one concentration (the size of the read-out at that concentration, not a potency): 54.4%
Compound 4: middle estimate off by 27.4 percentage points, on the low side; the whole stated range lies below it.
By their numbers in this assay, from the lowest: compound 1; then compounds 4, 3 and 2 (each within the scatter of the next, the first and the last beyond it).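

Pyrrolidin-1-yl in place of piperidin-1-yl, on this aromatic carbon next to the ring nitrogen, gives only a modest step here, a number 11.9 percentage points lower from compound 2 to compound 4 (beyond the scatter), in this assay. The effect of ring size at this position therefore depends on the core that carries it: the same change on two cores in this assay, a number 39.3 percentage points higher (beyond the scatter) from compound 1 to compound 3 and a number 11.9 percentage points higher (beyond the scatter) from compound 4 to compound 2, 27.4 percentage points apart, beyond the scatter of two such steps

The exchange on the oxygen, which stayed within the scatter with piperidin-1-yl, is also not neutral with pyrrolidin-1-yl, where it gives a number 32.2 percentage points higher from compound 1 to compound 4 (beyond the scatter): the same change on two cores in this assay, a number 4.8 percentage points lower (within the scatter) from compound 2 to compound 3 and a number 32.2 percentage points lower (beyond the scatter) from compound 4 to compound 1, 27.4 percentage points apart, beyond the scatter of two such steps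

The compounds shown leave open how a morpholine ring, an azepane ring or an open-chain dimethylamino group would behave at this position on either core. They also leave open whether this dependence on the core would persist across a full concentration series rather than at the one concentration tested.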